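Swapping the pyrimidinol of compound 3 for a bromothiophene

This account rests on a few compounds, and the source may have more. Where it says the series, first, only, none or still open, it means among the compounds named here.

Among the three measured compounds, compound 3 `Cc1nc(O)cc(C[S+]([O-])C(c2ccccc2)c2ccccc2)n1` stands lowest: in an assay on HEK293 cells for inhibition of sodium-dependent dopamine transporter (Homo sapiens), read by scintillation counting, with stated times of 5 min and 1 min (on this read-out lower numbers stand for stronger inhibition and higher numbers for weaker inhibition), compound 3 gives 3100 nM. Compound 2 `[O-][S+](Cc1csc(Br)c1)C(c1ccccc1)c1ccccc1` gives 16600 nM and compound 1 `[O-][S+](Cc1cc(C2CC2)on1)C(c1ccccc1)c1ccccc1` gives 38600 nM, so the step of a 5.4-fold lower number from compound 2 to compound 3 (0.73 log units; beyond the scatter) and the step of a 12-fold lower number from compound 1 to compound 3 (1.10 log units; beyond the scatter) both set compound 3 apart beyond the scatter.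

Compound 4 `[O-][S+](Cc1ccsc1Br)C(c1ccccc1)c1ccccc1` differs from compound 3 in one place: 2-bromothiophen-3-yl in place of 6-hydroxy-2-methylpyrimidin-4-yl on a saturated chain carbon bound to a sulfur. Going by the values given here, the step that bears most on this is the one from compound 2, which itself carries a bromothiophene on that chain carbon; there the step of a 5.4-fold lower number from compound 2 to compound 3 (0.73 log units; beyond the scatter) was modest, and compound 4 reverses that kind of exchange. The step of a 2.3-fold lower number from compound 1 to compound 2 (0.37 log units; beyond the scatter) shows that different bromothiophene and oxazole groups at this place stay within a modest range of one another.

Compound 4 is therefore expected to give a higher number than compound 3, by roughly the size of the step of a 4.5-fold higher number from compound 3 to compound 4 (0.65 log units; beyond the scatter), landing near compound 2. The estimate for compound 4 is 14000 nM, with a range from 5000 nM to 40000 nM.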

Compound 4, half-maximal inhibitory concentration: 29300 nM
Beside the measured number, compound 4's estimate is 2.1-fold (0.32 log units) below it; the range from low to high includes it.
By their numbers in this assay, from the lowest: compound 3; then compounds 2, 4 and 1 (each within the scatter of the next, the first and the last beyond it).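

In this assay, 2-bromothiophen-3-yl on a saturated chain carbon bound to a sulfur does not hold the number given by 6-hydroxy-2-methylpyrimidin-4-yl, with a 9.5-fold higher number from compound 3 to compound 4 (0.98 log units; beyond the scatter), a larger step than the one seen with the other bromothiophene. The exchange of one bromothiophene for the other cannot be told from scatter, with a 1.8-fold higher number from compound 2 to compound 4 (0.25 log units; within the scatter), and neither can the exchange of the oxazole for this bromothiophene, with a 1.3-fold lower number from compound 1 to compound 4 (0.12 log units; within the scatter), so the place of the bromine on the thiophene shows no effect of its own here. Nothing measured here explains these results.

From the compounds shown here alone, the 6-hydroxy-2-methylpyrimidin-4-yl group changes its hydroxy, its methyl and its ring nitrogens all at once, so which of them goes with the lower number of compound 3 stays open. A pyrimidine carrying an amine in place of the hydroxy would bear on that question.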